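Trimming the Amide Substituent: From Compound 2 to Compound 3

The source may report more compounds than this note shows. Statements on the series, on what has been measured and on what is new or still open speak of the compounds shown alone.

Of the compounds shown here, two have been measured. Compound 2 `C[C@@H](NC(=O)c1ccc(C#Cc2cccc(F)c2)cn1)C(C)(C)C` and compound 1 `Cc1nc(C#Cc2ccc(C(=O)N[C@H](C)C(C)(C)O)nc2)cs1` share the same core. In a functional assay on HEK293 cells for positive allosteric modulation of metabotropic glutamate receptor 5 (Rattus norvegicus), read by fluorescence and calcium flux (a lower number here means a smaller maximal response, a higher number a larger maximal response), compound 2 gives 66%, the lower of the two numbers, while compound 1 gives 66.6%; the gap lies within the scatter, so neither can be ranked above the other. Compound 3 `CCCNC(=O)c1ccc(C#Cc2cccc(F)c2)cn1` is not yet measured and differs from compound 2 in one place: propyl in place of 1,2,2-trimethylpropyl on an amide-type nitrogen. Within the data shown here, no measured pair shows this change, so its effect is unknown. Compound 3 is expected to give 60% (range 40% to 80%) in this assay. The expected step of a number 6 percentage points lower from compound 2 to compound 3 (within the scatter) is small and within the scatter.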

Compound 3, largest response reached (reported as efficacy), in percent of the reference or control that the assay uses: 65.9%
For compound 3 the middle estimate is 5.9 percentage points below the measured one; the range from low to high includes it.
By their numbers in this assay, from the lowest: compounds 3, 2 and 1 (each within the scatter of the next).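

Among these compounds, this is the first measured pair at this position: in this assay, propyl in place of 1,2,2-trimethylpropyl on the amide-type nitrogen gives a number 0.1 percentage points lower from compound 2 to compound 3 (within the scatter). The largest response therefore does not separate these two groups, although the defined stereocentre leaves with 1,2,2-trimethylpropyl. Within this pair, the full 1,2,2-trimethylpropyl group is not needed to keep that response.

On these data alone, whether a benzyl group or a carboxylic acid on this nitrogen would leave the response in the same place remains open. Nothing shown gives a reason for the result.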